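The compounds below may be only part of what the source reports. "The series", "measured", "known", "first", "only" and "open" are said of these compounds alone.

Three analogues sharing the same five-membered core were tested in an ADME assay on KB cells (Homo sapiens) for cytotoxicity, read by MTT assay, with a stated time of 72 h; on this read-out higher numbers stand for weaker inhibition and lower numbers for stronger inhibition. Compound 1, `COCOc1cc(C2=C(c3cc(OC)c(OC)c(OC)c3)C(=O)CC2O[SiH2]C(C)(C)C)ccc1OC`, is the only one of the three to return a number: in this assay compound 1 gives 33 ug/mL. Compound 2, `COc1ccc(C2=C(c3cc(OC)c(OC)c(OC)c3)C(=O)CC2C)cc1C(=O)O`, reaches only a limit of the assay, and in this assay compound 2 shows > 100 ug/mL. Compound 3, `CCOC(=O)COc1ccc(C2=C(c3cc(OC)c(OC)c(OC)c3)C(=O)CC2O)cc1`, likewise sits at a limit, giving > 100 ug/mL in this assay. Where compound 1 stands is therefore clear: it is the single resolved value, while the other two sit at the limit of > 100 ug/mL in this assay, at which 2 of the 3 values shown sit. Among the compounds with values here, no pair of these three differs in only one place, so no measured step can be read between them.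

The piece follows compound 1 to compound 4, `COc1cc(C2=C(c3cc(C)c(OC)c(C)c3)C(O[SiH2]C(C)(C)C)CC2=O)cc(OC)c1OC`, which has not yet been measured in this assay. The change is 4-methoxy-3,5-dimethylphenyl in place of 4-methoxy-3-(methoxymethoxy)phenyl on a double-bonded ring carbon. With no measured step of this kind in hand, the expectation rests on compound 1 alone, whose value of 33 ug/mL is the sole anchor. Compound 4 is expected to give 40 ug/mL, within a range from 10 ug/mL to 100 ug/mL. The step of a 1.2-fold higher number from compound 1 to compound 4 (0.08 log units; within the scatter) is accordingly expected to stay within the usual scatter, in no clear direction.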

Compound 4, half-maximal inhibitory concentration: 40 ug/mL
Beside the measured number, compound 4's estimate shows no gap at the digits printed; the measured number falls inside the stated range.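

In this assay, within the data shown here, the first step that can be read at this position is a 1.2-fold higher number from compound 1 to compound 4 (0.08 log units; within the scatter), so 4-methoxy-3,5-dimethylphenyl and 4-methoxy-3-(methoxymethoxy)phenyl on the double-bonded ring carbon cannot be told apart on this read-out. Among these compounds, the two groups are not alike in what is counted, since the one that leaves has 3 hydrogen-bond acceptors and the one that enters has 1, yet the read-out does not separate them, something the earlier compounds could not show because no pair among them differed in one place. Nothing measured here speaks to why the two groups read alike.

Still open, going by these compounds, is whether a phenyl group carrying an amine or a chlorine atom on this same ring carbon would read alike in this assay, as the two groups compared here carry only methyl, methoxy and methoxymethoxy substituents. Also open, on these data alone, is whether an acetate or a longer chain in place of the group of 6 heavy atoms shared by compound 1 and compound 4 would leave the number where it stands.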